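A few compounds are considered here, and "the series" means these few. Any claim that something is new, unique, unknown or untested is made for them only; others in the source may bear on it.

Measured so far in a functional assay on K562 cells (Homo sapiens) for cytotoxicity, read by fluorescence, with a stated time of 72 h; on this read-out higher numbers stand for weaker inhibition and lower numbers for stronger inhibition:
Compound 1 `Nc1nn(C(=O)c2ccc([N+](=O)[O-])cc2)c(N)c1/N=N/c1ccc(O)cc1` gives > 25000 nM as a limit
Compound 2 `CCOC(=O)n1nc(N)c(/N=N/c2ccc(O)cc2)c1N` gives > 100000 nM as a limit
Compound 3 `Cn1nc(N)c(/N=N/c2ccncc2)c1N` gives 67400 nM as a number

Compound 2 stands only at a limit (the limit of > 100000 nM in this assay, at which 1 of the 3 values shown sits). Compound 1 also gives only a limit (the limit of > 25000 nM in this assay, at which 1 of the 3 values shown sits). The next compound is compound 4 `Cn1nc(N)c(/N=N/c2ccc(O)cc2)c1N` with methyl in place of ethoxycarbonyl on an aromatic nitrogen. Among the compounds with values here, the one measured step at this carbonyl-bearing nitrogen is a step that the two limits leave unreadable from compound 1 to compound 2 and so offers no size to carry over. The nearest guide is compound 3 at 67400 nM as it carries the same methyl, although it differs from compound 4 elsewhere. On that single value, a step towards stronger inhibition is expected in this assay with only loose support. The expected step is an at least 1.6-fold lower number from compound 2 to compound 4 (0.22 log units; that floor lies within the scatter) and its size remains uncertain. For compound 4 the estimated value is 60000 nM with an expected range from 20000 nM to 150000 nM and a limit remains quite possible.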

Compound 4, half-maximal inhibitory concentration: 98500 nM
Beside the measured number, compound 4's estimate is 1.6-fold (0.22 log units) below it, and the stated range covers the measured number.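

With methyl on the aromatic nitrogen, compound 4 gives 98500 nM in this assay, the first number rather than a limit at this nitrogen for a compound otherwise matching compound 2. Compound 2 gives > 100000 nM, and this is a limit. The change therefore gives an at least 1.0-fold lower number from compound 2 to compound 4 (0.00 log units; that floor lies within the scatter), so replacing ethoxycarbonyl with methyl shows no gain that can be told from the scatter, although the size of any true step could be larger.

As far as these compounds go, the size of that step stays open while one end of it is only a limit, and the earlier step between the two carbonyl-bearing groups cannot be read either. Also open, from the compounds shown here alone, is whether a group of another kind on this nitrogen, such as benzyl or a longer chain ending in an amine, would give a lower number.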